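The compounds below may be only part of what the source reports. "The series", "measured", "known", "first", "only" and "open" are said of these compounds alone.

Measured compounds:
- compound 1, `CN1CCC(c2coc3ccc(NC(=O)c4ccc(F)cc4)nc23)CC1`, 3.1 nM
- compound 2, `CN1CCC(c2coc3ccc(NC(=O)c4c(F)cccc4Cl)nc23)CC1`, 2.9 nM

Both were tested in an assay on isolated protein for binding affinity to 5-hydroxytryptamine receptor 1F (Homo sapiens); a lower number here means a stronger inhibitor, a higher number a weaker inhibitor. Compound 2 gives the lowest of the two numbers, but its neighbour compound 1 is so close that a 1.1-fold lower number from compound 1 to compound 2 (0.03 log units; within the scatter); the two cannot be told apart on these data.

Compound 3, `CN1CCC(c2coc3ccc(NC(=O)c4ccc(F)cc4Cl)nc23)CC1`, is not yet measured. It differs from compound 2 in one place: 2-chloro-4-fluorophenyl in place of 2-chloro-6-fluorophenyl on a carbonyl carbon. Within the data shown here, the only measured step that bears on this kind of change is the one from compound 1 to compound 2, where the substituents on the phenyl attached to the carbonyl carbon were rearranged and the number barely moved, a 1.1-fold lower number from compound 1 to compound 2 (0.03 log units; within the scatter). On that evidence, a further rearrangement of the same substituents is expected to give no step beyond the scatter, a 1.1-fold higher number from compound 2 to compound 3 (0.04 log units; within the scatter). Compound 3 is therefore estimated at 3.2 nM, within a range of 1.5 nM to 7 nM.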

Compound 3, inhibition constant: 3 nM
Beside the measured number, compound 3's estimate is 1.1-fold (0.03 log units) above it, and the stated range covers the measured number.
By their numbers in this assay, from the lowest: compounds 2, 3 and 1 (each within the scatter of the next).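

In this assay, 2-chloro-4-fluorophenyl in place of 2-chloro-6-fluorophenyl on the carbonyl carbon leaves the number within the scatter (a 1.0-fold higher number from compound 2 to compound 3 (0.01 log units; within the scatter)), so among these compounds this rearrangement of the same two substituents shows no measurable effect. Compound 3 also isolates a single added atom, chloro in place of hydrogen on an aromatic carbon, and that change also stays within the scatter (a 1.0-fold lower number from compound 1 to compound 3 (0.01 log units; within the scatter)). Nothing available here explains why these numbers stay so close.

Every phenyl shown carries only chloro or fluoro, so it remains open whether a methoxy group, an amine or a carboxylic acid on that ring would keep the number in the same range. The compounds also leave open what an unsubstituted phenyl would give.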